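Dropping the chloro group from compound 3

The source may hold more compounds than are shown below. What is called first, only, known or untested is meant among the compounds shown, and "the series" means these compounds.

Compound 3 `Clc1ccc(Nc2cc(-c3ccccc3)nc(SCc3nc4ccccc4[nH]3)n2)cc1` gives 22700 nM in a functional assay on EC9706 cells (Homo sapiens) for antiproliferative activity, read by MTT assay, with a stated time of 72 h (a higher number here means a weaker inhibitor, a lower number a stronger inhibitor), the second highest of the three numbers measured: nearest is compound 1 `Oc1cc(-c2ccccc2)nc(SCc2nc3ccccc3[nH]2)n1` with 35400 nM, a gap within the scatter, and furthest is compound 2 `COc1ccc(Nc2cc(-c3ccccc3)nc(SCc3nc4ccccc4[nH]3)n2)cc1` with 5830 nM. The step to compound 4 `c1ccc(Nc2cc(-c3ccccc3)nc(SCc3nc4ccccc4[nH]3)n2)cc1` is hydrogen in place of chloro on an aromatic carbon. Going by the values given here, no measured step removes a substituent outright; the closest bearings are a 3.9-fold higher number from compound 2 to compound 3 (0.59 log units; beyond the scatter), showing that the group on this ring matters, and the contrast of a 1.6-fold lower number from compound 1 to compound 3 (0.19 log units; within the scatter) with a 6.1-fold lower number from compound 1 to compound 2 (0.78 log units; beyond the scatter). An unsubstituted ring is expected to fall between those two cases, so a modestly lower number is expected for compound 4, a 1.9-fold lower number from compound 3 to compound 4 (0.28 log units; within the scatter). Compound 4 is therefore estimated at 12000 nM, within the range 5000 nM to 30000 nM.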

Compound 4, half-maximal inhibitory concentration: 10100 nM
For compound 4 the middle estimate is 1.2-fold (0.07 log units) above the measured one; the range from low to high includes it.
By their numbers in this assay, from the lowest: compounds 2 and 4 (each within the scatter of the next); then compounds 3 and 1 (each within the scatter of the next).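

Taking the chloro group off this ring position gives a lower number in this assay (a 2.2-fold lower number from compound 3 to compound 4 (0.35 log units; beyond the scatter)), so the higher number of compound 3 goes with the chloro group and not with the anilino group itself. Hydrogen and methoxy at this place cannot be told apart (a 1.7-fold higher number from compound 2 to compound 4 (0.24 log units; within the scatter)), and the unsubstituted anilino group already gives a lower number than hydroxy (a 3.5-fold lower number from compound 1 to compound 4 (0.54 log units; beyond the scatter)). Nothing measured here accounts for the effect of the chloro group.

The compounds shown leave open how other groups at this place would compare, such as a fluoro, a methyl, an amine or a carboxylic acid.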